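This account rests on a few compounds, and the source may have more. Where it says the series, first, only, none or still open, it means among the compounds named here.

Working notes on the series in a functional assay on the whole organism (blood, strain Wistar-Okamoto) with Rattus norvegicus as the target, with a stated time of 5 days; on this read-out lower numbers stand for an effect already at smaller amounts and higher numbers for an effect only at larger amounts of compound.

Compound 1 `N#CN/C(=N\C1CC1)Nc1cccnc1` gives 20 mg/kg in this assay. Among the compounds with values here, compound 2 `N#CN/C(=N\Cc1ccco1)Nc1cccnc1` gives 20 mg/kg, and the step of no change at the digits printed from compound 1 to compound 2 (within the scatter) is the only measured change so far: (furan-2-yl)methyl in place of cyclopropyl on a double-bonded nitrogen left the minimum effective dose where it was. Compound 2 therefore stands level with compound 1 at the digits shown, within the scatter, and neither can be called the more potent of the two.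

Compound 3 `N#CN/C(=N\c1ccccc1)Nc1cccnc1` has not been measured. It differs from compound 2 as follows: phenyl in place of (furan-2-yl)methyl on a double-bonded nitrogen. Within the data shown here, the one measured step bears on it only loosely, since it exchanged two groups at the same double-bonded nitrogen and produced no change, which suggests that this position tolerates a different group without moving the dose. Phenyl is a third, untested group there, so the guide is thin. The expected step is no change at the digits printed from compound 2 to compound 3 (within the scatter), with no change beyond the scatter. Compound 3 is estimated at 20 mg/kg, with a range from 7 mg/kg to 60 mg/kg.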

Compound 3, minimum effective dose: 5 mg/kg
Estimate against measurement, compound 3: 4.0-fold (0.60 log units) above; the whole stated range lies above it.
By their numbers in this assay, from the lowest: compound 3; then compounds 1 and 2 (each within the scatter of the next).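

In this assay, the double-bonded nitrogen no longer looks indifferent to its group, as the level pair of compound 1 and compound 2 alone had suggested: phenyl in place of (furan-2-yl)methyl gives a 4.0-fold lower number from compound 2 to compound 3 (0.60 log units; beyond the scatter) and phenyl in place of cyclopropyl gives a 4.0-fold lower number from compound 1 to compound 3 (0.60 log units; beyond the scatter) in the same direction. Compound 3 thus has the lowest number of the three, and heavy-atom count does not account for the difference from compound 2, since (furan-2-yl)methyl and phenyl have the same count, with a five-membered aromatic ring carrying a hetero atom leaving and a six-membered aromatic ring of carbon only entering. Nothing at hand shows what lies behind the lower number with phenyl.

On these data alone, whether the gain belongs to phenyl specifically remains open, as benzyl would test the same six-membered ring with a carbon link to the nitrogen, and 2-pyridyl would test a hetero atom in that ring. Also open, as far as these compounds go, is how chloro or methoxy substituents on the phenyl ring, or a longer alkyl chain in its place, would move the minimum effective dose.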